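Half-life of an Amidine Ester Series in Plasma

The source may hold more compounds than are shown below. What is called first, only, known or untested is meant among the compounds shown, and "the series" means these compounds.

Compound 1: `CCOC(=O)CN(C(=O)/C(C)=C/c1ccc(C(=O)Oc2ccc(C(=N)N)cc2)cc1)C1CCCC1` — < 0.0834 h
Compound 2: `C/C(=C\c1ccc(C(=O)Oc2ccc(C(=N)N)cc2)cc1)C(=O)N(CC(=O)O)C1CCCC1` — 0.383 h

Of the compounds shown here, two have been measured in an in vitro ADME assay on a cell-free system (plasma) for pharmacokinetics; on this read-out lower numbers stand for a shorter-lived compound and higher numbers for a longer-lived compound. For compound 1 the value is only a limit of the assay (the limit of < 0.0834 h in this assay, at which 1 of the 2 values shown sits). In this assay, for the measured compounds named here, compound 2 gives 0.383 h, the sole actual number among the two values shown, so compound 2 stands alone as the reference point. Going by the values given here, the one measured step is an at least 4.5-fold higher number from compound 1 to compound 2 (0.66 log units; beyond the scatter), which shows the free acid outlasting its ethyl ester.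

The next compound, compound 3 `C=CCN(CCC(=O)O)C(=O)/C(C)=C/c1ccc(C(=O)Oc2ccc(C(=N)N)cc2)cc1`, keeps the free acid and the rest of the shared core of compound 2 but changes the amide substituents: allyl(2-carboxyethyl)amino in place of (carboxymethyl)(cyclopentyl)amino on a carbonyl carbon. Among the compounds with values here, no measured step covers a change of this kind; the only step known concerns the ester versus the acid, and the acid is retained here, so that step gives no direction for this one. No step beyond the scatter is therefore expected.

Compound 3 is thus estimated to give 0.38 h, with a range from 0.15 h to 1 h. The expected step is a 1.0-fold lower number from compound 2 to compound 3 (0.00 log units; within the scatter).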

Compound 3, half-life: 0.783 h
Compound 3: the middle estimate sits 2.1-fold (0.31 log units) below what was measured; low and high end bracket the measured number.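

In this assay, the amide substituents on the carbonyl carbon prove to matter in their own right: allyl(2-carboxyethyl)amino in place of (carboxymethyl)(cyclopentyl)amino gives a 2.0-fold higher number from compound 2 to compound 3 (0.31 log units; beyond the scatter). The earlier step concerned only the ethyl ester against the free acid, whereas this one shows that the number still moves with the free acid kept, and that a substituent without a ring can stand here without any loss on this read-out. The single step bundles three differences, since the cyclopentyl ring leaves, the allyl group enters and carboxymethyl becomes 2-carboxyethyl, and nothing shown here accounts for the rise.

As far as these compounds go, what stays open is which of these differences carries the step, a question that would need cyclopentyl paired with 2-carboxyethyl, or allyl paired with carboxymethyl, to be settled. Also open, from the compounds shown here alone, is whether a longer chain such as 3-carboxypropyl, a saturated propyl group in place of allyl, or a tetrazole in place of the carboxylic acid would move the number further in either direction.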